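Ethyl to ethylsulfanyl on the shared core

The source may report more compounds than this note shows. Statements on the series, on what has been measured and on what is new or still open speak of the compounds shown alone.

Two compounds of this series carry numbers in a functional assay for inhibition of sodium/hydrogen exchanger (Oryctolagus cuniculus); on this read-out higher numbers stand for weaker inhibition and lower numbers for stronger inhibition. Compound 1 `CCN(CC)Cc1cc(Br)c(S(C)(=O)=O)cc1C(=O)N=C(N)N` gives 9500 nM in this assay. Compound 2 `CCc1cc(C)c(C(=O)N=C(N)N)cc1S(C)(=O)=O` gives 4.8 nM in this assay; this is the lowest of the two numbers, and the only other, compound 1, stands at a far higher number, well beyond the scatter. Going by the values given here, no pair of measured compounds differs in one place only, so no single step has been measured so far.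

Compound 3 `CCSc1cc(C)c(C(=O)N=C(N)N)cc1S(C)(=O)=O` is the next compound, not yet measured in this assay. Against compound 2 the change is ethylsulfanyl in place of ethyl on an aromatic carbon. The rest of the structure, with the methylsulfonyl group, the methyl group and the group of six heavy atoms on the same ring, is kept.

Nothing measured bears on an exchange of ethyl for ethylsulfanyl here. With only one heavy atom added, a small step is expected, in either direction, and most likely within the scatter. The expected step is a 1.5-fold higher number from compound 2 to compound 3 (0.16 log units; within the scatter), leaning toward a slightly higher number. Compound 3 is expected at about 7 nM in this assay, within a range of 2 nM to 25 nM.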

Compound 3, half-maximal inhibitory concentration: 5.9 nM
Compound 3: the middle estimate sits 1.2-fold (0.07 log units) above what was measured; the measured number falls inside the stated range.
By their numbers in this assay, from the lowest: compounds 2 and 3 (each within the scatter of the next); then compound 1.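

In this assay, ethylsulfanyl in place of ethyl on this aromatic carbon, ortho to a methylsulfonyl group and para to a group of 6 heavy atoms, gives a 1.2-fold higher number from compound 2 to compound 3 (0.09 log units; within the scatter). Going by these compounds alone, this is the first single-place step, and it shows that this position accepts the sulfur atom, the extra heavy atom and the hydrogen-bond acceptor counted for ethylsulfanyl with no change beyond the scatter, and compound 3 stays in the low range at 5.9 nM. No measurement available here accounts for this outcome, so the step stands as an observation only.

As far as these compounds go, both ethyl and ethylsulfanyl are small uncharged groups, so it remains open whether the same holds for a longer chain such as butyl, for an ethylsulfonyl group, or for a charged group such as an amine or a carboxylic acid at this carbon. Compound 1 differs from compound 2 and compound 3 in more than one place, so the large gap to its number cannot yet be assigned to any single part of the structure.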